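This account rests on a few compounds, and the source may have more. Where it says the series, first, only, none or still open, it means among the compounds named here.

Measured so far:
Compound 1, `COc1cc(/C=C/C(=O)C2=C(/C=C/c3ccc(O)c(OC)c3)NC(=O)NC2c2ccccc2O)ccc1O`: in a functional assay, with a stated time of 20 min, tested at 10 uM (on this read-out lower numbers stand for a weaker effect and higher numbers for a stronger effect at the one concentration tested), compound 1 gives 71%.
Compound 2, `COc1cc(/C=C/C(=O)C2=C(/C=C/c3ccc(O)c(OC)c3)NC(=O)NC2c2ccc(N(C)C)cc2)ccc1O`: in this assay compound 2 gives 69.9%.

Compound 2 and compound 1 lie within the scatter of each other, so the two numbers cannot be told apart. For the measured compounds named here, the one step measured so far is a number 1.1 percentage points lower from compound 1 to compound 2 (within the scatter), a change of the group on a saturated ring carbon that left the read-out unchanged beyond the scatter.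

Compound 3, `COc1cc(/C=C/C(=O)C2=C(/C=C/c3ccc(O)c(OC)c3)NC(=O)NC2c2cccc([N+](=O)[O-])c2)ccc1O`, has not been measured. It differs from compound 2 in this way: 3-nitrophenyl in place of 4-(dimethylamino)phenyl on a saturated ring carbon. Going by the values given here, this is again a change of the group on the same saturated ring carbon, and the only comparable step, from compound 1 to compound 2, stayed within the scatter. For compound 3 no step beyond the scatter is therefore expected; the estimated step is a number 0.1 percentage points higher from compound 2 to compound 3 (within the scatter). In this assay compound 3 is expected to give about 70%, with a likely range from 58% to 82%.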

Compound 3, a percentage reported as activity, at one concentration (the size of the read-out at that concentration, not a potency): 19.9%
Compound 3: middle estimate off by 50.1 percentage points, on the high side; measured number outside the range, below it.
By their numbers in this assay, from the lowest: compound 3; then compounds 2 and 1 (each within the scatter of the next).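

The saturated ring carbon bearing the aryl group can strongly affect the read-out in this assay, even though the first change there made no difference beyond the scatter. Placing 3-nitrophenyl on this carbon gives a large step from either earlier group, 4-(dimethylamino)phenyl (a number 50 percentage points lower from compound 2 to compound 3 (beyond the scatter)) or 2-hydroxyphenyl (a number 51.1 percentage points lower from compound 1 to compound 3 (beyond the scatter)). Nothing measured here explains this loss of effect.

The three compounds differ in both the group carried on the phenyl ring and where it sits, so they cannot show which of the two matters. A plain phenyl ring would give a reference without any added group, and an amine in place of the nitro group at the same ring position would test whether the nitro group itself goes with the low number.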